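This account rests on a few compounds, and the source may have more. Where it says the series, first, only, none or still open, it means among the compounds named here.

Compound 1 `CC(C)c1cc(OCC(=O)[C@H](CC(=O)O)NC(=O)[C@@H](NC(=O)COc2cccc3ccccc23)C(C)C)no1` in a functional assay on Jurkat cells (Homo sapiens) for inhibition (on this read-out higher numbers stand for weaker inhibition and lower numbers for stronger inhibition), gives only a limit, > 200000 nM. Compound 2 `CC(C)[C@H](NC(=O)COc1cccc2ccccc12)C(=O)N[C@@H](CC(=O)O)C(=O)CSc1nc(-c2ccccc2)cs1` in this assay likewise gives only a limit, > 200000 nM. Among the compounds with values here, compound 3 `CC(C)[C@H](NC(=O)COc1cccc2ccccc12)C(=O)N[C@@H](CC(=O)O)C(=O)CSc1nc(-c2ccccc2)no1` is the one compound with a number: in this assay compound 3 gives 102000 nM. Two of the three values sit at the limit of > 200000 nM in this assay, at which 2 of the 3 values shown sit, so the steps read as an at least 1.9-fold lower number from compound 1 to compound 3 (0.29 log units; that floor lies within the scatter) and an at least 1.9-fold lower number from compound 2 to compound 3 (0.29 log units; that floor lies within the scatter), while a step that the two limits leave unreadable from compound 1 to compound 2. Compound 4 `CC(C)[C@H](NC(=O)COc1cccc2ccccc12)C(=O)N[C@@H](CC(=O)O)C(=O)CSc1nncn1C` carries 4-methyl-4H-1,2,4-triazol-3-yl in place of 3-phenyl-1,2,4-oxadiazol-5-yl on a sulfur. Within the data shown here, of the measured steps, only the exchange of one aromatic ring on the same sulfur bears on this change, and it stayed within the scatter; no step covers loss of the phenyl-bearing ring. The number for compound 4 is therefore expected to lie near that of compound 3 or above it, with the step of a 1.6-fold higher number from compound 3 to compound 4 (0.20 log units; within the scatter) as the estimate. Compound 4 is estimated at 160000 nM, between 60000 nM and 400000 nM.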

Compound 4, half-maximal inhibitory concentration: > 200000 nM
Compound 4 ended at the assay's limit (the forecaster's own chance of this, stated with the estimate: 45%); at least 1.2-fold (0.09 log units) between middle value and limit.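

In this assay, within the data shown here, the exchange on the sulfur gives an at least 1.9-fold higher number from compound 3 to compound 4 (0.29 log units; that floor lies within the scatter), so the one number in the set does not survive replacing 3-phenyl-1,2,4-oxadiazol-5-yl with 4-methyl-4H-1,2,4-triazol-3-yl. This is the first compound shown at this position whose ring carries no phenyl group, and that ring does not lift compound 4 off the limit, > 200000 nM. The steps to compound 4 from compound 1 and compound 2 cannot be read, and compound 3 stays the only compound with a number: the limit of > 200000 nM in this assay, at which 3 of the 4 values shown sit.

On these data alone, how far compound 4 really lies from compound 3 remains open, since its value is only a limit. Also open, as far as these compounds go, is whether a phenyl ring carrying a methoxy group or a fluorine, or a 4-methyl-4H-1,2,4-triazol-3-yl ring bearing a phenyl group, would give a readable number on this sulfur.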